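Chlorine on the benzyl arm: from compound 3 to compound 4

The compounds below may be only part of what the source reports. "The series", "measured", "known", "first", "only" and "open" are said of these compounds alone.

Measured so far in a functional assay on the whole organism (artery, strain albino) with Rattus norvegicus as the target, with a stated time of 180 min, at a dose of 10 mg/kg by the oral route; on this read-out higher numbers stand for more inhibition at the one dose given (going by the name of the read-out) and lower numbers for less inhibition:
compound 1 `CC1=C(C(=O)Nc2ccc([N+](=O)[O-])cc2)C(c2ccc(Br)cc2)N=C(SCc2ccccc2)N1` gives 19.6%
compound 2 `CC1=C(C(=O)Nc2ccc([N+](=O)[O-])cc2)C(c2ccc(Br)cc2)N=C(SCc2ccccc2Cl)N1` gives 11.3%
compound 3 `CC1=C(C(=O)Nc2ccc([N+](=O)[O-])cc2)C(c2cccc([N+](=O)[O-])c2)N=C(SCc2ccccc2)N1` gives 16.5%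

Compound 3 holds the second highest of these three numbers. Its nearest neighbour is compound 1, whose number is slightly higher, and the furthest is compound 2, whose number is slightly lower; both gaps fall within the usual scatter, so no real order can be read from them.

Compound 4 `CC1=C(C(=O)Nc2ccc([N+](=O)[O-])cc2)C(c2cccc([N+](=O)[O-])c2)N=C(SCc2ccccc2Cl)N1` is the unmeasured compound. It differs from compound 3 in one place: chloro in place of hydrogen on an aromatic carbon. The place is an aromatic carbon of the benzyl group, ortho to a large group.

Within the data shown here, one measured step bears directly on this change, because it is the same exchange made on the pair of compounds that carry a 4-bromophenyl instead of a 3-nitrophenyl: a number 8.3 percentage points lower from compound 1 to compound 2 (within the scatter). That step pointed downward but stayed within the scatter. The corresponding step here is therefore expected to be small and downward, a number 6 percentage points lower from compound 3 to compound 4 (within the scatter), and may well not be beyond the scatter.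

The number expected for compound 4 in this assay is 10.5%, with a range from 0% to 22%.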

Compound 4, a percentage reported as inhibition, in the whole organism at one dose (the size of the read-out at that dose, not a potency): 9.3%
Estimate against measurement, compound 4: 1.2 percentage points above, within the range that was stated.
By their numbers in this assay, from the lowest: compounds 4, 2, 3 and 1 (each within the scatter of the next, the first and the last beyond it).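

In this assay, chloro in place of hydrogen on the benzyl arm has now been read on a second core, with a 3-nitrophenyl group in place of 4-bromophenyl, and the step is a number 7.2 percentage points lower from compound 3 to compound 4 (within the scatter). With compounds 1 to 4 complete as a square of two changes, the chloro exchange reads nearly the same on both cores, although neither reading lies beyond the scatter: the same change on two cores in this assay, a number 8.3 percentage points lower (within the scatter) from compound 1 to compound 2 and a number 7.2 percentage points lower (within the scatter) from compound 3 to compound 4, 1.1 percentage points apart, within the scatter of two such steps The other change can now also be read with chloro present, as a number 2 percentage points lower from compound 2 to compound 4 (within the scatter), and within these four compounds it too reads nearly the same whether or not the chloro is there: the same change on two cores in this assay, a number 3.1 percentage points lower (within the scatter) from compound 1 to compound 3 and a number 2 percentage points lower (within the scatter) from compound 2 to compound 4, 1.1 percentage points apart, within the scatter of two such steps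

The compounds shown leave open whether a different group at this place on the benzyl arm, such as a methoxy group, an amine or a carboxylic acid, would give a step beyond the scatter. From the compounds shown here alone, each number is also the size of the read-out at a single dose, so how these compounds would compare at other doses remains open.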